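Swapping the bromophenyl arm for an iodoethenyl chain

This account rests on a few compounds, and the source may have more. Where it says the series, first, only, none or still open, it means among the compounds named here.

Of the compounds shown here, three have been tested in an assay on PC-12 cells for displacement of a labelled ligand from vesicular acetylcholine transporter (Homo sapiens) (on this read-out higher numbers stand for weaker inhibition and lower numbers for stronger inhibition), and none has given a number. Compound 1 `OC1CN(Cc2ccc(Br)cc2)CCC1N1CCN(c2ccccc2)CC1` reaches only the limit of the assay, > 100 nM. Compound 2 `OC1CN(C/C=C/I)CCC1N1CCN(c2ccccc2)CC1` likewise gives only the limit, > 100 nM. Between these two the step that the two limits leave unreadable from compound 1 to compound 2 runs from one limit to the other, so its size cannot be read. Compound 3 `OC1CCN(Cc2ccc(Br)cc2)CC1N1CCN(c2ccccc2)CC1` also stands at the limit, > 100 nM. Among the compounds with values here, all three values sit at the limit of > 100 nM in this assay, at which 3 of the 3 values shown sit, so nothing has yet produced a readable potency and no compound can be set above or below another.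

Compound 4 `OC1CCN(C/C=C/I)CC1N1CCN(c2ccccc2)CC1` has not been measured. It differs from compound 3 by 2-iodoethenyl in place of 4-bromophenyl on a saturated chain carbon bound to an amine nitrogen in a ring. Within the data shown here, the only measured step of the same kind, a step that the two limits leave unreadable from compound 1 to compound 2, is unreadable and gives neither size nor direction. The expected step is therefore a step that the limit leaves unreadable from compound 3 to compound 4, with no direction beyond the scatter that the data could support. Compound 4 is estimated at 300 nM, within 100 nM to 3000 nM, and is expected most likely to be reported once more as a limit rather than a number.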

Compound 4, half-maximal inhibitory concentration: > 100 nM
Compound 4 ended at the assay's limit (the forecaster's own chance of this, stated with the estimate: 85%); the middle value does not contradict the limit.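

In this assay compound 4 gives > 100 nM, a limit of the assay and not a number. No new step can be read, since compound 3 and compound 4 both stand at a limit, and so do all the others: the limit of > 100 nM in this assay, at which 4 of the 4 values shown sit.

The compounds shown leave open whether 2-iodoethenyl and 4-bromophenyl differ at all in this assay.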